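Bromo on the phenyl ring of compound 3

This account rests on a few compounds, and the source may have more. Where it says the series, first, only, none or still open, it means among the compounds named here.

Compound 1 `O=c1[nH]c(-c2ccccc2O)nc2c1cnn2-c1ccc(Br)cc1`: 338 nM
Compound 2 `Nc1ccccc1NCc1nc2c(cnn2-c2ccccc2)c(=O)[nH]1`: 6800 nM
Compound 3 `O=c1[nH]c(CNc2ccccc2O)nc2c1cnn2-c1ccccc1`: 250 nM
Compound 4 `O=c1[nH]c(CNc2ccccc2O)nc2c1cnn2-c1ccc(Br)cc1`: not yet measured

In a functional assay on corpus cavernosum (Rattus norvegicus) for activation (on this read-out lower numbers stand for an effect already at smaller amounts and higher numbers for an effect only at larger amounts of compound), compound 3 gives 250 nM, within the usual scatter of compound 1 at 338 nM. Compound 3 lies well clear of compound 2, with a 27-fold lower number from compound 2 to compound 3 (1.43 log units; beyond the scatter).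

Compound 4 differs from compound 3 by bromo in place of hydrogen on an aromatic carbon, turning phenyl into 4-bromophenyl (bromo in place of hydrogen on an aromatic carbon). Going by the values given here, the one measured step is hydroxy in place of amino, a different change, so its large size says nothing about bromo. Among the compounds with values here, compound 1 also carries 4-bromophenyl, but no measured compound forms a matching partner without the bromo. With no direct evidence for this change, the expectation in this assay is no shift beyond the scatter, starting from compound 3 at 250 nM. The expected result is a 1.1-fold lower number from compound 3 to compound 4 (0.06 log units; within the scatter). For compound 4 the estimate is 220 nM, with an expected range from 70 nM to 700 nM.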

Compound 4, half-maximal effective concentration: 5050 nM
Beside the measured number, compound 4's estimate is 23-fold (1.36 log units) below it; measured number outside the range, above it.
By their numbers in this assay, from the lowest: compounds 3 and 1 (each within the scatter of the next); then compounds 4 and 2 (each within the scatter of the next).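

In this assay, turning phenyl into 4-bromophenyl gives a 20-fold higher number from compound 3 to compound 4 (1.31 log units; beyond the scatter) and so a single bromine on this aromatic ring is enough to move the effect to much larger amounts of compound. The earlier compounds could not show this, as compound 1 also carries 4-bromophenyl but has no shown partner without the bromo, so this is the first direct reading of the change. No measurement shown here explains the size of this step.

Going by these compounds, it remains open whether this loss belongs to bromo in particular or would also follow from another group on the same carbon, such as fluoro, chloro, methyl or methoxy. On these data alone, it also remains open whether removing the bromo from compound 1 would produce a step of similar size.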